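The source may report more compounds than this note shows. Statements on the series, on what has been measured and on what is new or still open speak of the compounds shown alone.

Measured so far:
- compound 1 `CCC(CC)Nc1ncnc2c1ncn2C1O[C@H](CO)[C@@H](O)[C@H]1O`: 0.75 nM
- compound 2 `CCCn1c(=O)c2nc(C(O)(CC)CC)[nH]c2n(CCC)c1=O`: 170 nM

In an assay on cell membranes for binding affinity to adenosine receptor A1 (Cavia porcellus), read by radioligand binding (a higher number here means a weaker inhibitor, a lower number a stronger inhibitor), compound 1 gives 0.75 nM and compound 2 gives 170 nM. Compound 2 stands at the higher of the two numbers, the weaker of the pair, and its gap to compound 1 lies well beyond the scatter. The two share no single point of difference, so their gap says nothing about any one substituent.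

Compound 3 `CCCn1c(=O)c2nc([C@@H]3CC4C=CC3C4)[nH]c2n(CCC)c1=O` keeps the core of compound 2 and differs from it in one place: a group of 7 heavy atoms (7 carbon; 2 five-membered non-aromatic rings of carbon only) in place of a group of 6 heavy atoms (5 carbon, 1 oxygen; no ring), on an aromatic carbon. Within the data shown here, no measured step of this kind exists in the set, so the size of the change is a guess rather than a reading off a neighbour. The expectation is a fall, a step of a 34-fold lower number from compound 2 to compound 3 (1.53 log units; beyond the scatter), larger than the scatter. Compound 3 is expected to give 5 nM, within 1 nM to 30 nM.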

Compound 3, inhibition constant: 4.3 nM
Beside the measured number, compound 3's estimate is 1.2-fold (0.07 log units) above it; measured number inside the range.
By their numbers in this assay, from the lowest: compound 1; then compound 3; then compound 2.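

At this place, on an aromatic carbon of a five-membered aromatic ring with 2 nitrogen, in this assay the exchange of 1-ethyl-1-hydroxypropyl for the all-carbon group with 2 five-membered non-aromatic rings gives a 40-fold lower number from compound 2 to compound 3 (1.60 log units; beyond the scatter) as a large step. Among these compounds, this is the first single-place step, and it shows that the number responds strongly to the group at this position on the core shared by these two compounds, which the earlier pair could not show. No measured evidence bears on the reason for this fall.

The change swaps the oxygen, the ring system, the double bond and the defined stereocentre together, so the step cannot be assigned to any one of them. A 1-ethylpropyl group or a cyclopentyl group at this place would begin to separate these features.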